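Aryl amino swap on the shared core: hydroxyphenyl to difluorophenyl

The compounds below may be only part of what the source reports. "The series", "measured", "known", "first", "only" and "open" are said of these compounds alone.

Compound 2 `COc1cc(OC)cc(Oc2ncccc2-c2n[nH]c(Nc3cccc(O)c3)n2)c1` stands highest of the two numbers in a functional assay on A-431 cells (Homo sapiens), tested at 0.1 uM (a higher number here means more inhibition at the concentration tested (going by the name of the read-out), a lower number less inhibition), giving 86%. Compound 1 `COc1ccc(CNc2ncccc2-c2n[nH]c(Nc3ccc4c(c3)OCCO4)n2)cc1` gives 30% in this assay, a gap beyond the scatter; compound 1 differs from compound 2 in more than one place, so no single step can be read from that pair. Compound 3 `COc1cc(OC)cc(Oc2ncccc2-c2n[nH]c(Nc3cc(F)cc(F)c3)n2)c1` is not yet measured. It differs from compound 2 as follows: 3,5-difluorophenyl in place of 3-hydroxyphenyl on a nitrogen on an aromatic ring. For the measured compounds named here, no measured step shows the effect of this change. The expected step of a number 21 percentage points lower from compound 2 to compound 3 (beyond the scatter) is a moderate loss of inhibition, beyond the scatter. For compound 3 the estimate is 65%, range 35% to 90%.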

Compound 3, a percentage reported as inhibition, at one concentration (the size of the read-out at that concentration, not a potency): 27%
Estimate against measurement, compound 3: 38 percentage points above, outside the stated range (below it).
By their numbers in this assay, from the lowest: compounds 3 and 1 (each within the scatter of the next); then compound 2.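

In this assay, 3,5-difluorophenyl in place of 3-hydroxyphenyl on a nitrogen on an aromatic ring costs much of the inhibition (a number 59 percentage points lower from compound 2 to compound 3 (beyond the scatter)). For the compounds shown here, this is the first single-place step, and it shows that inhibition at this position depends strongly on which aryl group is attached. Nothing available explains the size of this step.

With both the hydroxyl and the fluorines changing in a single step, their contributions cannot be separated. Plain phenyl, 3-methoxyphenyl or 3-aminophenyl at this position could help to separate them.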